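Aryl exchange on the chain of compound 3: working notes

The compounds below may be only part of what the source reports. "The series", "measured", "known", "first", "only" and "open" are said of these compounds alone.

Compound 3 `O=C(/C=C/c1ccccc1Cl)Nc1ccc2ncnc(Nc3cccc(Cl)c3)c2c1` gives 4.58 ug/mL in a functional assay on A549 cells (Homo sapiens) for antiproliferative activity, read by MTT assay, with a stated time of 48 h (on this read-out higher numbers stand for weaker inhibition and lower numbers for stronger inhibition), the second highest of the three numbers seen so far. Compound 2 `COc1ccccc1/C=C/C(=O)Nc1ccc2ncnc(Nc3cccc(Br)c3)c2c1` gives 3.55 ug/mL and compound 1 `O=C(/C=C/c1ccccc1Cl)Nc1ccc2ncnc(Nc3cccc(Br)c3)c2c1` gives 6.63 ug/mL, and both sit within the scatter of compound 3. The measured steps are a 1.9-fold lower number from compound 1 to compound 2 (0.27 log units; within the scatter) and a 1.4-fold lower number from compound 1 to compound 3 (0.16 log units; within the scatter), each a single-substituent swap on an aromatic ring. Compound 4 `O=C(/C=C/c1cccc2ccccc12)Nc1ccc2ncnc(Nc3cccc(Cl)c3)c2c1` differs from compound 3 by naphthalen-1-yl in place of 2-chlorophenyl on a double-bonded chain carbon bound to a double-bonded chain carbon. Going by the values given here, no measured step exchanges one ring system for another; the nearest comparison, the substituent swap on the same chain-end ring in the first step, stayed within the scatter. For compound 4 the expected step in this assay is a 1.0-fold lower number from compound 3 to compound 4 (0.01 log units; within the scatter), none beyond the scatter. Compound 4 is therefore estimated at 4.5 ug/mL, with a range from 2 ug/mL to 10 ug/mL.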

Compound 4, half-maximal inhibitory concentration: 1.49 ug/mL
The estimate for compound 4 lay 3.0-fold (0.48 log units) above the measured number; the whole stated range lies above it.
By their numbers in this assay, from the lowest: compound 4; then compounds 2, 3 and 1 (each within the scatter of the next).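

In this assay, going by these compounds alone, naphthalen-1-yl in place of 2-chlorophenyl gives a 3.1-fold lower number from compound 3 to compound 4 (0.49 log units; beyond the scatter) and is the first step beyond the scatter. The earlier single-substituent swaps stayed within the scatter, so this position on the double-bonded chain carbon is now seen to respond to an exchange of the whole aryl group. Nothing on hand explains this step. As far as these compounds go, whether the lower number persists with an amine or a carboxylic acid on the naphthalen-1-yl group remains open. Also open, from the compounds shown here alone, is whether it persists with bromo in place of chloro on the aromatic carbon.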